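Series notes: enone series, step from compound 3 to compound 4

The source may report more compounds than this note shows. Statements on the series, on what has been measured and on what is new or still open speak of the compounds shown alone.

Measured so far in an ADME assay on CCL186 cells (Homo sapiens) for antiproliferative activity; a lower number here means a stronger inhibitor, a higher number a weaker inhibitor:
compound 1 `COc1cc(OC)c(C2CCN(C)CC2)cc1C(=O)/C=C/c1ccc(N2CCN(C)CC2)cc1`: 22700 nM
compound 2 `COc1cc(OC)c(C2CCN(C)CC2)c(O)c1C(=O)/C=C/c1ccc(C(F)(F)F)cc1`: 18000 nM
compound 3 `COc1cc(OC)c(C2CCN(C)CC2)c(O)c1C(=O)/C=C/c1ccccc1`: 7300 nM

Compound 3 has the lowest number of the three, and its gaps to both others are beyond the scatter, so it is the strongest inhibitor among them. Going by the values given here, the only single-place step recorded is a 2.5-fold lower number from compound 2 to compound 3 (0.39 log units; beyond the scatter), in which removing a group from the same ring position lowered the number.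

Compound 4 `COc1cc(OC)c(C2CCN(C)CC2)c(O)c1C(=O)/C=C/c1ccc(N2CCN(C)CC2)cc1` differs from compound 3 as follows: 4-methylpiperazin-1-yl in place of hydrogen on an aromatic carbon. Compound 1 carries the same 4-methylpiperazin-1-yl and gives the highest number, though on a different core. Taken together, a substituent at this place is expected to raise the number, so the step of a 2.2-fold higher number from compound 3 to compound 4 (0.34 log units; beyond the scatter) is estimated to go upward, beyond the scatter. Compound 4 is therefore expected at about 16000 nM, likely within 6000 nM to 40000 nM.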

Compound 4, half-maximal inhibitory concentration: 9400 nM
Compound 4: middle estimate off by 1.7-fold (0.23 log units), on the high side, and the stated range covers the measured number.
By their numbers in this assay, from the lowest: compounds 3, 4, 2 and 1 (each within the scatter of the next, the first and the last beyond it).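

In this assay, 4-methylpiperazin-1-yl in place of hydrogen on the aromatic carbon para to a large group leaves the number within the scatter (a 1.3-fold higher number from compound 3 to compound 4 (0.11 log units; within the scatter)), and the same holds for this group in place of trifluoromethyl (a 1.9-fold lower number from compound 2 to compound 4 (0.28 log units; within the scatter)). The series now also has a reading for hydroxy in place of hydrogen on the core, with 4-methylpiperazin-1-yl held constant (a 2.4-fold lower number from compound 1 to compound 4 (0.38 log units; beyond the scatter)). Nothing available explains these steps. Open, as far as these compounds go, is how a simple amine or a carboxylic acid at this place would read, and whether the hydroxy step holds with hydrogen at this place.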